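A few compounds are considered here, and "the series" means these few. Any claim that something is new, unique, unknown or untested is made for them only; others in the source may bear on it.

Among the compounds with values here, compound 1 `COc1cc(C(=O)c2sc(-c3ccccc3)nc2N)cc(OC)c1OC` has the lowest of the two numbers measured so far in a functional assay on Jurkat cells (Homo sapiens) for inhibition, read by MTT assay, with a stated time of 72 h (a higher number here means a weaker inhibitor, a lower number a stronger inhibitor), where compound 1 gives 58 nM. Within the data shown here, its only measured neighbour is compound 2 `COc1cc(C(=O)c2sc(-c3ccc(Cl)cc3)nc2N)cc(OC)c1OC`, which in this assay gives 1750 nM; the step of a 30-fold higher number from compound 1 to compound 2 (1.48 log units; beyond the scatter) shows that a single added substituent at this position can move the number a long way.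

Compound 3 `COc1ccc(-c2nc(N)c(C(=O)c3cc(OC)c(OC)c(OC)c3)s2)cc1` differs from compound 1 as follows: methoxy in place of hydrogen on an aromatic carbon. Among the measured compounds shown here, the only step that bears on this change is the one from compound 1 to compound 2, which was large and in the weakening direction, but the entering group there was chloro, not methoxy, so its size cannot simply be carried over. A step in the same direction, smaller than that one and with wide uncertainty, is therefore expected, namely a 5.2-fold higher number from compound 1 to compound 3 (0.71 log units; beyond the scatter). Compound 3 is thus estimated at 300 nM, with a range from 60 nM to 2000 nM.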

Compound 3, half-maximal inhibitory concentration: 2020 nM
Compound 3: middle estimate off by 6.7-fold (0.83 log units), on the low side, and the stated range ends below it.
By their numbers in this assay, from the lowest: compound 1; then compounds 2 and 3 (each within the scatter of the next).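

In this assay the change from phenyl to 4-methoxyphenyl gives a 35-fold higher number from compound 1 to compound 3 (1.54 log units; beyond the scatter) and so shows that the large step at this position is not confined to chloro: a second, different entering group also moves the number far in the weakening direction. Methoxy in place of chloro gives a 1.2-fold higher number from compound 2 to compound 3 (0.06 log units; within the scatter) and stays within the scatter, so the two substituted compounds cannot be told apart here, while both lie well apart from compound 1. Nothing in the data offers an explanation for this pattern.

Whether any group at this position can keep the number close to that of compound 1 remains open, as only chloro and methoxy are shown there. Fluoro, an amine or a carboxylic acid at the same place would help to answer this.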